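Chain lengthening in a trifluoromethyl ketone series

This account rests on a few compounds, and the source may have more. Where it says the series, first, only, none or still open, it means among the compounds named here.

Measured in an assay for inhibition of liver carboxylesterase (Sus scrofa), with a stated time of 15 min; a higher number here means a weaker inhibitor, a lower number a stronger inhibitor:
Compound 1, `CCCCCCCCCC[S+]([O-])CC(=O)C(F)(F)F`: 3.2 nM
Compound 2, `CCCCCCCCCCCC[S+]([O-])CC(=O)C(F)(F)F`: 8.6 nM
Compound 3, `CCCCCCCCCCS(=O)(=O)CC(=O)C(F)(F)F`: 28 nM

Compound 3 stands at the highest of the three numbers in this assay; the values of compound 2 and compound 1 lie below it, compound 1 furthest.

Compound 4, `CCCCCCCCCCCCS(=O)(=O)CC(=O)C(F)(F)F`, differs from compound 3 by ethyl in place of hydrogen on a saturated chain carbon, ten or more bonds along the chain from a sulfonyl sulfur. For the measured compounds named here, the one measured step that bears on this is the same change in the sulfoxide pair, a 2.7-fold higher number from compound 1 to compound 2 (0.43 log units; beyond the scatter). On that basis a comparable modest rise in the number is expected, a 2.7-fold higher number from compound 3 to compound 4 (0.43 log units; beyond the scatter), since nothing measured points the other way.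

Compound 4 is therefore estimated at 75 nM in this assay, within a range of 30 nM to 200 nM.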

Compound 4, half-maximal inhibitory concentration: 46 nM
For compound 4 the middle estimate is 1.6-fold (0.21 log units) above the measured one, within the range that was stated.
By their numbers in this assay, from the lowest: compound 1; then compound 2; then compounds 3 and 4 (each within the scatter of the next).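

In this assay, ethyl in place of hydrogen on this saturated chain carbon gives a 1.6-fold higher number from compound 3 to compound 4 (0.22 log units; within the scatter), so on the sulfonyl core this change has no effect that can be told from scatter. The clear step seen in the sulfoxide pair is thus not reproduced as a clear step here, yet the two steps cannot be told apart either: the same change on two cores in this assay, a 2.7-fold higher number (0.43 log units; beyond the scatter) from compound 1 to compound 2 and a 1.6-fold higher number (0.22 log units; within the scatter) from compound 3 to compound 4, 1.6-fold (0.21 log units) apart, within the scatter of two such steps

From the compounds shown here alone, whether a longer chain would move the number on either core remains open. So does the effect of an amine or a carboxylic acid at this position.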